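This account rests on a few compounds, and the source may have more. Where it says the series, first, only, none or still open, it means among the compounds named here.

Of the compounds shown here, three built on one shared core have been tested in an ADME assay on the whole organism with Oryza sativa as the target, tested at 0.1 uM; on this read-out higher numbers stand for a weaker effect at the one concentration tested and lower numbers for a stronger effect. Among the compounds with values here, compound 1 `CCCCCCc1ccc(NC(=O)N[C@@H](C)c2ccccc2)cc1` gives 99%, and compound 2 `CC(=O)c1ccc(NC(=O)N[C@@H](C)c2ccccc2)cc1` gives 99%; the only single-point step among them, no change at the digits printed from compound 1 to compound 2 (within the scatter), is flat. Compound 3 `C[C@@H](NC(=O)Nc1ccc(Br)cc1)c1ccccc1` gives 100%, a number that sits with those of compound 1 and compound 2, every gap lying within the scatter. The next compound, compound 4 `C[C@H](NC(=O)Nc1ccc(Br)cc1)c1ccccc1`, differs from compound 3 in this way: the two compounds have the same atoms and bonds and differ only in configuration as drawn: 1 of 1 stereo elements differ; a stereocentre at a saturated chain carbon is drawn R in compound 3 and S in compound 4. Within the data shown here, no measured step in this assay concerns a change of configuration, so the flat step seen from compound 1 to compound 2 is the only guide, and it points to nothing beyond the scatter. For compound 4 the expected result is 99%, between 93% and 100%, meaning an expected step of a number 1 percentage points lower from compound 3 to compound 4 (within the scatter).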

Compound 4, a percentage reported as activity, at one concentration (the size of the read-out at that concentration, not a potency): 98%
Compound 4: middle estimate off by 1 percentage points, on the high side; low and high end bracket the measured number.
By their numbers in this assay, from the lowest: compounds 4, 1, 2 and 3 (each within the scatter of the next).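

In this assay, the stereocentre at the saturated chain carbon can be judged on its own: the fact that compounds 3 and 4 differ only in the configuration as drawn. Redrawing it from R to S gives a number 2 percentage points lower from compound 3 to compound 4 (within the scatter), so this first test of configuration shows no step beyond the scatter. Swapping the group on the aromatic carbon stays just as flat for bromo in place of acetyl, with a number 1 percentage points lower from compound 2 to compound 4 (within the scatter), and for bromo in place of hexyl, with a number 1 percentage points lower from compound 1 to compound 4 (within the scatter).

From the compounds shown here alone, whether an amine or a carboxylic acid on that aromatic carbon would move the read-out stays open. So does whether the R and S forms would part with such a group in place.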